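Swapping Fluoro for Methylsulfanyl at the Assay Limit

The compounds below may be only part of what the source reports. "The series", "measured", "known", "first", "only" and "open" are said of these compounds alone.

Measured so far:
- compound 1, `O=c1c2cc(F)ccc2ccn1[C@@H]1O[C@H](COP(=O)(O)OP(=O)(O)OP(=O)(O)O)[C@@H](O)[C@H]1O`: > 20000 nM
- compound 2, `O=c1c2cc(F)c(F)cc2ccn1[C@@H]1O[C@H](COP(=O)(O)OP(=O)(O)OP(=O)(O)O)[C@@H](O)[C@H]1O`: > 20000 nM

Both compounds share one core and differ only in the number of fluoro groups on the carbon-only aromatic ring. In a functional assay for agonist activity at P2Y purinoceptor 1 (Homo sapiens), read by FLIPR (a lower number here means that less compound is needed, a higher number that more compound is needed for the effect), compound 1 gives > 20000 nM, which is a limit of the assay and not a number. In this assay compound 2 likewise gives > 20000 nM, again a limit rather than a measured number. The step that the two limits leave unreadable from compound 1 to compound 2 therefore cannot be read, because both ends sit at the limit of > 20000 nM in this assay, at which 2 of the 2 values shown sit.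

Compound 3, `CSc1cc2ccn([C@@H]3O[C@H](COP(=O)(O)OP(=O)(O)OP(=O)(O)O)[C@@H](O)[C@H]3O)c(=O)c2cc1F`, is not yet measured. It differs from compound 2 by methylsulfanyl in place of fluoro on an aromatic carbon. Among the measured compounds shown here, the only measured step is unreadable, so no step bears on this change in a usable way, and the two limits give no direction to lean on. Compound 3 is therefore expected to stay near the same region, with an estimated step that the limit leaves unreadable from compound 2 to compound 3 step from compound 2. Compound 3 is estimated at 30000 nM in this assay, within a range from 4000 nM to 200000 nM.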

Compound 3, half-maximal effective concentration: > 20000 nM
Compound 3: a limit, no number; the forecaster's own chance of this, stated with the estimate: 70%; the middle value is on the limit's open side.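

In this assay compound 3 gives > 20000 nM, which is a limit of the assay and not a number. No step among compound 1, compound 2 and compound 3 can be read, because all three rest at the same limit: the limit of > 20000 nM in this assay, at which 3 of the 3 values shown sit.

The compounds shown leave open how fluoro, methylsulfanyl and hydrogen at this place compare, since none yields a measured number.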